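Compound 4: one step further along the chain

The compounds below may be only part of what the source reports. "The series", "measured", "known", "first", "only" and "open" are said of these compounds alone.

In a functional assay on HeLa cells (Homo sapiens) for antiproliferative activity, read by MTT assay, with a stated time of 48 h (a higher number here means a weaker inhibitor, a lower number a stronger inhibitor), compound 1 (`COc1ccc(N(C)c2ccnc(Cl)n2)cc1O`) gives 96 nM, compound 2 (`COc1ccc(N(C)c2ccnc(Cl)n2)cc1OCC[Se]C#N`) gives 436 nM and compound 3 (`COc1ccc(N(C)c2ccnc(Cl)n2)cc1OCCC[Se]C#N`) gives 4710 nM. Compound 3 therefore has the highest number of the three and is the weakest inhibitor so far.

Compound 4 (`COc1ccc(N(C)c2ccnc(Cl)n2)cc1OCCCC[Se]C#N`) comes from compound 3 by a group of 4 heavy atoms (2 carbon, 1 nitrogen, 1 selenium; no ring) in place of a group of 3 heavy atoms (1 carbon, 1 nitrogen, 1 selenium; no ring), on a saturated chain carbon, three bonds along the chain from an oxygen on an aromatic ring, on a saturated chain carbon, three bonds along the chain from an oxygen on an aromatic ring.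

Among the compounds with values here, three measured steps bear on this change. Substitution on the oxygen gave a modest 4.5-fold higher number from compound 1 to compound 2 (0.66 log units; beyond the scatter) and a large 49-fold higher number from compound 1 to compound 3 (1.69 log units; beyond the scatter). Within the data shown here, the closest precedent is the same kind of replacement two bonds along the chain, which gave a large 11-fold higher number from compound 2 to compound 3 (1.03 log units; beyond the scatter). Among the measured compounds shown here, all three steps run towards a higher number, and no compound here goes against that. For the measured compounds named here, still, only this one step compares two chain lengths, and the data do not show whether the rise continues or levels off.

A further moderate move to a higher number is therefore expected in this assay, with less confidence in its size than in its direction. The expected change is a 2.5-fold higher number from compound 3 to compound 4 (0.41 log units; beyond the scatter). For compound 4 the estimated value is 12000 nM, with an expected range of 3000 nM to 40000 nM.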

Compound 4, half-maximal inhibitory concentration: > 10000 nM
Compound 4: no number, only a limit; the forecaster's own chance of this, stated with the estimate: 15%; the middle value does not contradict the limit.
By their numbers in this assay, from the lowest: compound 1; then compound 2; then compound 3. At a limit, above all of these: compound 4.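

In this assay compound 4 gives > 10000 nM, which is a limit of the assay and not a number: the limit of > 10000 nM in this assay, at which 1 of the 4 values shown sits.

Lengthening the chain at this position, on a saturated chain carbon, three bonds along the chain from an oxygen on an aromatic ring, still moves activity in the same direction, with an at least 2.1-fold higher number from compound 3 to compound 4 (0.32 log units; beyond the scatter); the rise therefore does not level off at compound 3. Across the set, the result extends to an at least 22-fold higher number from compound 2 to compound 4 (1.36 log units; beyond the scatter) and to an at least 100-fold higher number from compound 1 to compound 4 (2.01 log units; beyond the scatter), so that among these compounds each longer chain carries a higher number than the shorter one, the free phenol of compound 1 has the lowest number, and no compound goes against this order.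

On these data alone, the limit hides the true size of the last step, so whether it is larger or smaller than an 11-fold higher number from compound 2 to compound 3 (1.03 log units; beyond the scatter) remains open. As far as these compounds go, the effect of a plain alkyl chain or a chain ending in an amine or a carboxylic acid on the same oxygen also remains open, and the loss cannot yet be divided between chain length and the end group carrying selenium and the nitrile.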